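Swapping the Halogenated Ring on a Hydrazone Carbon

The source may report more compounds than this note shows. Statements on the series, on what has been measured and on what is new or still open speak of the compounds shown alone.

Of the compounds shown here, three built on one shared core have been tested in a functional assay on MGC-803 cells (Homo sapiens) for antiproliferative activity, read by MTT assay, with a stated time of 72 h; on this read-out lower numbers stand for stronger inhibition and higher numbers for weaker inhibition. Compound 1 `CCCSc1nc(N/N=C(\C)c2ccccc2O)c2nnn(Cc3ccco3)c2n1` gives 4760 nM. Going by the values given here, compound 3 `CCCSc1nc(N/N=C(\C)c2ccccc2O)c2nnn(Cc3cccc(Cl)c3)c2n1` gives 6500 nM in this assay, and the single one-place step among the measured compounds, a 1.4-fold higher number from compound 1 to compound 3 (0.14 log units; within the scatter), is the only guide to how a change at one place moves the number here. Compound 2 `CCCSc1nc(N/N=C/c2ccccc2Cl)c2nnn(Cc3ccccc3)c2n1` gives 10900 nM, the highest of the three numbers; its gap to compound 3 lies within the scatter, while its gap to compound 1 lies beyond it.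

Compound 4 `CCCSc1nc(N/N=C/c2ccc(Br)cc2)c2nnn(Cc3ccccc3)c2n1` has not yet been measured. It differs from compound 2 in one place: 4-bromophenyl in place of 2-chlorophenyl on a carbon with a double bond to nitrogen. Among the compounds with values here, no measured step touches this part of the molecule, and the one step that is known, a 1.4-fold higher number from compound 1 to compound 3 (0.14 log units; within the scatter), lay within the scatter. There is therefore no basis for expecting a step in this assay beyond the scatter in either direction. Compound 4 is expected to give about 10000 nM, with a range from 4000 nM to 25000 nM. The expected step is a 1.1-fold lower number from compound 2 to compound 4 (0.04 log units; within the scatter).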

Compound 4, half-maximal inhibitory concentration: 34900 nM
Beside the measured number, compound 4's estimate is 3.5-fold (0.54 log units) below it, and the stated range ends below it.
By their numbers in this assay, from the lowest: compounds 1, 3 and 2 (each within the scatter of the next, the first and the last beyond it); then compound 4.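

Going by these compounds alone, replacing 2-chlorophenyl with 4-bromophenyl on a carbon with a double bond to nitrogen gives a 3.2-fold higher number from compound 2 to compound 4 (0.51 log units; beyond the scatter) in this assay, so this position can move the number beyond the scatter, which the one earlier step, at a different place, did not do. The two groups have the same counts of heavy atoms, hydrogen-bond donors and acceptors and the same lack of charge, so those counts do not separate them, while the halogen and its place on the ring both change in this single step. Nothing measured here explains the weaker inhibition.

This step alone cannot show whether the bromine or its place on the ring matters more, a question that 4-chlorophenyl and 2-bromophenyl would address. Also open, going by these compounds, is how an unsubstituted phenyl, or a phenyl bearing an amine, would behave at this position.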